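Changing the benzyl group on the shared core

The source may hold more compounds than are shown below. What is called first, only, known or untested is meant among the compounds shown, and "the series" means these compounds.

Compound 1 `N#Cc1ccc(Cn2cc(COc3ccc4c(=O)ccoc4c3)nn2)cc1` carries 4-cyanophenyl on a saturated chain carbon bound to an aromatic nitrogen. In an ADME assay on L02 cells (Homo sapiens) for cytotoxicity, read by MTT assay, with a stated time of 48 h (a lower number here means a stronger inhibitor, a higher number a weaker inhibitor), compound 1 gives only a limit, > 300000 nM. Compound 2 `O=c1ccoc2cc(OCc3cn(Cc4cccc(F)c4)nn3)ccc12` carries 3-fluorophenyl at that place. In this assay compound 2 also gives only a limit, > 300000 nM. The step that the two limits leave unreadable from compound 1 to compound 2 therefore cannot be read. Compound 2 thus stands at the limit (the limit of > 300000 nM in this assay, at which 2 of the 2 values shown sit), with no number to place it.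

Compound 3 `Cc1ccccc1Cn1cc(COc2ccc3c(=O)ccoc3c2)nn1` differs from compound 2 as follows: 2-methylphenyl in place of 3-fluorophenyl on a saturated chain carbon bound to an aromatic nitrogen. For the measured compounds named here, the only measured step at this place is a step that the two limits leave unreadable from compound 1 to compound 2, and its size is unreadable, so it gives no direction to expect for compound 3. Both measured compounds sit at the limit in this assay, and the change is again an exchange of one substituted phenyl for another at the same saturated chain carbon. Compound 3 is therefore expected to sit at the limit as well, so that the step of a number no higher from compound 2 to compound 3 (the limit leaves the size open) is estimated to show no readable change. The estimate for compound 3 in this assay is 300000 nM, with a range from 100000 nM to 1000000 nM, and most likely only a limit will be reported.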

Compound 3, half-maximal inhibitory concentration: > 300000 nM
Compound 3: only a limit was reported; the forecaster's own chance of this, stated with the estimate: 85%; the middle value lies on the limit itself.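

In this assay compound 3 gives only a limit, as do compound 1 and compound 2, so no new step among these compounds can be read: the limit of > 300000 nM in this assay, at which 3 of the 3 values shown sit.

The compounds shown leave open whether 4-cyanophenyl, 3-fluorophenyl and 2-methylphenyl differ at all in this assay, and at what concentration any of the three would reach half-maximal inhibition.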